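Compound 3: 2-fluorobenzyl to 3-chlorobenzyl

This account rests on a few compounds, and the source may have more. Where it says the series, first, only, none or still open, it means among the compounds named here.

Going by the values given here, only two compounds have numbers so far in a functional assay on PC-3 cells (Homo sapiens) for cytotoxicity, read by MTT assay, with a stated time of 24 h; a higher number here means a weaker inhibitor, a lower number a stronger inhibitor. Compound 1 (`COc1ccc(/C=C2\CN(C(=S)SCc3cn(Cc4ccccc4F)nn3)C/C(=C\c3ccc(OC)cc3)C2=O)cc1`) gives 31500 nM and compound 2 (`Cc1ccc(/C=C2\CN(Cc3cn(Cc4ccc(F)cc4)nn3)C/C(=C\c3ccc(C)cc3)C2=O)cc1`) gives 65600 nM as its value. Compound 1 holds the lower number of the two, with a gap beyond the usual scatter, which makes it the stronger of this pair. The two differ in more than one place, so the gap isolates no single change.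

Compound 3 (`COc1ccc(/C=C2\CN(C(=S)SCc3cn(Cc4cccc(Cl)c4)nn3)C/C(=C\c3ccc(OC)cc3)C2=O)cc1`) is still unmeasured and keeps the core of compound 1. The change is 3-chlorophenyl in place of 2-fluorophenyl on a saturated chain carbon bound to an aromatic nitrogen.

Among the compounds with values here, no measured step covers this substituent, so the expectation in this assay rests on compound 1 at 31500 nM alone. No step beyond the scatter is expected, and no direction is favoured. The estimate amounts to an expected 1.1-fold lower number from compound 1 to compound 3 (0.02 log units; within the scatter) as the step. For compound 3 the estimated value is 30000 nM, with 14000 nM to 65000 nM as the expected range.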

Compound 3, half-maximal inhibitory concentration: > 80000 nM
Compound 3 ended at the assay's limit; the forecaster's own chance of this, stated with the estimate: 10%; middle value at least 2.6-fold (0.42 log units) from the limit.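

In this assay compound 3 gives > 80000 nM, which is a limit of the assay and not a number. Going by these compounds alone, the first single-place step, 3-chlorophenyl in place of 2-fluorophenyl on a saturated chain carbon bound to an aromatic nitrogen, gives an at least 2.5-fold higher number from compound 1 to compound 3 (0.40 log units; beyond the scatter), so the aryl group at this place affects the read-out, a point the earlier pair, which differs in more than one place, could not show. The step is a lower bound on its size, and its true size stays unknown: the limit of > 80000 nM in this assay, at which 1 of the 3 values shown sits.

The change replaces the fluorine with chlorine and also moves the halogen on the ring, so the compounds shown do not separate the effect of the element from that of its ring position; 3-fluorobenzyl or 2-chlorobenzyl at this place would separate the two. From the compounds shown here alone, whether any group here gives a lower number than 2-fluorobenzyl also stays open, and unsubstituted benzyl or a benzyl bearing a methoxy group would extend the comparison on the core of compound 1.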